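The source may report more compounds than this note shows. Statements on the series, on what has been measured and on what is new or still open speak of the compounds shown alone.

Compound 1 `COc1ccc2[nH]c(-c3ccccc3)c(C(c3c(-c4ccccc4)[nH]c4ccc(C)cc34)C3C(=O)NN=C3C)c2c1` and compound 2 `CC1=NNC(=O)C1C(c1c(-c2ccccc2)[nH]c2ccccc12)c1c(-c2ccccc2)[nH]c2ccc(C)cc12` share a core built from two indole rings joined through a pyrazolone-bearing carbon, and they differ in one place: hydrogen in place of methoxy on an aromatic carbon. In a functional assay on HeLa cells (Homo sapiens) for cytotoxicity, read by MTT assay (a higher number here means a weaker inhibitor, a lower number a stronger inhibitor), compound 1 gives > 100000 nM, which is a limit of the assay rather than a number. Compound 2 gives > 100000 nM in this assay, again a limit. The step that the two limits leave unreadable from compound 1 to compound 2 is therefore not readable, because of the limit of > 100000 nM in this assay, at which 2 of the 3 values shown sit. Compound 3 `COc1ccc2[nH]c(-c3ccccc3)c(C(c3c[nH]c4ccccc34)C3C(=O)NN=C3C)c2c1` carries a different core; how it differs from the core of compound 1 is not broken down here. In this assay compound 3 gives 1700 nM. Compound 4 `CC1=NNC(=O)C1C(c1c[nH]c2ccccc12)c1c(-c2ccccc2)[nH]c2ccccc12` makes the same kind of change on that core: hydrogen in place of methoxy on an aromatic carbon. Since the measured pair gives no readable size, the step from compound 3 to compound 4 is expected to be small, a 1.8-fold higher number from compound 3 to compound 4 (0.25 log units; within the scatter). Compound 4 is estimated at 3000 nM, between 900 nM and 15000 nM.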

Compound 4, half-maximal inhibitory concentration: 7700 nM
Compound 4: the middle estimate sits 2.6-fold (0.41 log units) below what was measured, and the stated range covers the measured number.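

In this assay, putting hydrogen in place of methoxy on an aromatic carbon gives a 4.5-fold higher number from compound 3 to compound 4 (0.66 log units; beyond the scatter), so on this core the change gives a modestly weaker compound. This single pair gives the size of the change on one core only, and it does not show that the same size holds on another core. The matching step on the core of compound 1 cannot be read, because both of its values are limits, not numbers: the limit of > 100000 nM in this assay, at which 2 of the 4 values shown sit.

The compounds shown leave open what an amine, a carboxylic acid or a longer chain such as ethoxy would give on that aromatic carbon. Also open, as far as these compounds go, is how the change behaves on a further core where both values are numbers.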